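From naphthalen-1-yl to 3,4,5-trimethoxyphenyl on compound 1

This account rests on a few compounds, and the source may have more. Where it says the series, first, only, none or still open, it means among the compounds named here.

Within the data shown here, in a functional assay on THP-1 cells (Homo sapiens) for inhibition, read by sulforhodamine B assay, with a stated time of 48 h, tested at 50 uM (a lower number here means less inhibition of growth, a higher number more inhibition of growth at the concentration tested), compound 1 (`COc1cc(/C=C/C(=O)/C=C/c2cccc3ccccc23)ccc1OCc1cn(CCOc2cc(=O)oc3ccccc23)nn1`) gives 89% and holds the highest of the three numbers so far, beyond the scatter from both of the others. Compound 2 (`COc1cc(/C=C/C(=O)/C=C/c2cccc3ccccc23)ccc1OCc1cn(CCCCCOc2cc(=O)oc3ccccc23)nn1`) gives 44% while compound 3 (`COc1ccccc1/C=C/C(=O)/C=C/c1ccc(OCc2cn(CCCOc3cc(=O)oc4ccccc34)nn2)c(OC)c1`) gives 50% and these two values lie within the scatter of each other.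

Compound 4 (`COc1cc(/C=C/C(=O)/C=C/c2cc(OC)c(OC)c(OC)c2)ccc1OCc1cn(CCOc2cc(=O)oc3ccccc23)nn1`) keeps the rest of compound 1 and carries 3,4,5-trimethoxyphenyl in place of naphthalen-1-yl on a double-bonded chain carbon bound to a double-bonded chain carbon. Among the measured compounds shown here, no measured pair isolates this exchange, so its size remains uncertain. Compound 1 at 89% leaves little room for a rise, so a fall is the more likely direction. The expected change is a number 29 percentage points lower from compound 1 to compound 4 (beyond the scatter) in this assay and this estimated fall would lie beyond the scatter. For compound 4 the estimated value is 60% with an expected range from 35% to 85% when it is measured.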

Compound 4, percent growth inhibition at one concentration: 99%
Compound 4: the middle estimate sits 39 percentage points below what was measured, and the stated range ends below it.
By their numbers in this assay, from the lowest: compounds 2 and 3 (each within the scatter of the next); then compounds 1 and 4 (each within the scatter of the next).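

In this assay the exchange of naphthalen-1-yl for 3,4,5-trimethoxyphenyl on a double-bonded chain carbon bound to a double-bonded chain carbon gives a number 10 percentage points higher from compound 1 to compound 4 (within the scatter) and so shows that this position accepts one aromatic ring in place of two, and three hydrogen-bond acceptors in place of none, with no change beyond the scatter. Among these compounds, this is the first step that can be read at this position, since the earlier compounds offered no pair differing in one place. No measurement shown here accounts for the result.

From the compounds shown here alone, it remains open whether a plain phenyl, an amine or a carboxylic acid at this position would keep the growth inhibition seen with compound 4. Going by these compounds, it is also open whether the same exchange would have a similar outcome on the core of compound 2.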